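The source may report more compounds than this note shows. Statements on the series, on what has been measured and on what is new or still open speak of the compounds shown alone.

In a functional assay on the whole organism (Abdomen, strain Swiss) for inhibition, with Mus musculus as the target, with stated times of 30 min, 10 min and 5 min, at a dose of 20 mg/kg by the oral route (on this read-out lower numbers stand for a weaker effect and higher numbers for a stronger effect at the one dose given), the measured compounds are:
compound 1 `C=Cc1c(CCC)nn(CCCN2CCN(c3ccc(C)cc3)CC2)c(=O)c1N` gives 7%;
compound 2 `CC/C=C/c1c(C)nn(CCCN2CCN(c3ccc(C)cc3)CC2)c(=O)c1N` gives 35%;
compound 3 `Cc1c(C#N)c(-c2ccccc2)nn1CCCN1CCN(c2cccc(Cl)c2)CC1` gives 0%.

Compound 3 holds the lowest of the three numbers in this assay, but the number of compound 1 differs from it only within the usual scatter; only compound 2 lies beyond the scatter above it.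

Compound 4 `Cc1ccc(N2CCN(CCCn3nc(-c4ccccc4)c(C#N)c3C)CC2)cc1` differs from compound 3 in a single place: 4-methylphenyl in place of 3-chlorophenyl on an amine nitrogen in a ring. Among the compounds with values here, no measured pair shows this change by itself, so its effect cannot be read from these compounds. Compounds 1 and 2 carry 4-methylphenyl, and in this assay compound 1 gives 7% while compound 2 gives 35%, yet their cores differ from the core of compound 3, so they do not isolate the change.

A small step is expected, a number 8 percentage points higher from compound 3 to compound 4 (within the scatter), upward if anything and probably not beyond the scatter. Compound 4 is estimated at 8%, with a range from 0% to 25%.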

Compound 4, a percentage reported as inhibition, in the whole organism at one dose (the size of the read-out at that dose, not a potency): 8%
Compound 4: middle estimate and measured number agree at the digits printed, and the stated range covers the measured number.
By their numbers in this assay, from the lowest: compounds 3, 1 and 4 (each within the scatter of the next); then compound 2.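

Placing 4-methylphenyl in place of 3-chlorophenyl on an amine nitrogen in a ring gives the first direct reading of this change. In this assay the change gives a number 8 percentage points higher from compound 3 to compound 4 (within the scatter) and so does not separate the two groups on this core. Nothing measured here offers an explanation for this result.

As far as these compounds go, it remains open whether an unsubstituted phenyl or a pyridine ring at this position would move the number beyond the scatter. Also open, from the compounds shown here alone, is whether the same swap would give so small a step on the core of compound 2.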